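Replacing Phenyl with Methyl on a Pyranone-Bearing Dihydropyridine

This account rests on a few compounds, and the source may have more. Where it says the series, first, only, none or still open, it means among the compounds named here.

Of the compounds shown here, three have been measured in an assay on isolated protein (strain albino) for inhibition of Voltage-dependent L-type calcium channel subunit alpha-1C (Cavia porcellus); on this read-out higher numbers stand for weaker inhibition and lower numbers for stronger inhibition. Compound 1 `CCOC(=O)C1=C(C)NC(C)=C(C(=O)OCC)C1c1ccc(-c2cc(=O)cc(-c3ccccc3)o2)cc1` gives 12200 nM in this assay. Compound 2 `CCOC(=O)C1=C(C)NC(C)=C(C(=O)OCC)C1c1ccc(-c2cc(=O)cc(C)o2)cc1` gives 2140 nM in this assay and differs from compound 1 in one place only: methyl in place of phenyl on an aromatic carbon. This single change produced a 5.7-fold lower number from compound 1 to compound 2 (0.76 log units; beyond the scatter), a clear gain in inhibition.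

Compound 3 `CCOC(=O)C1=C(C)NC(C)=C(C(=O)OC)C1c1cc(=O)cc(-c2ccccc2)o1` carries a different core, and the difference between the two cores is not broken down here. In this assay compound 3 gives 2030 nM. That number sits within the usual scatter of the number for compound 2, so the two cannot be ordered, while the number for compound 1 lies clearly higher than that of compound 3.

Compound 4 `CCOC(=O)C1=C(C)NC(C)=C(C(=O)OC)C1c1cc(=O)cc(C)o1` is not yet measured. It relates to compound 3 exactly as compound 2 relates to compound 1: methyl in place of phenyl on an aromatic carbon. The surroundings of the change are described in the same words for both pairs, so it is the same change, now applied to the core of compound 3.

Because compound 1 to compound 2 gave a 5.7-fold lower number from compound 1 to compound 2 (0.76 log units; beyond the scatter), a step of similar size is expected here, namely a 4.5-fold lower number from compound 3 to compound 4 (0.65 log units; beyond the scatter). That expectation rests on a single precedent, so a wide range is kept. In this assay compound 4 is estimated to give 450 nM, most likely between 150 nM and 1500 nM.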

Compound 4, half-maximal inhibitory concentration: 1630 nM
Estimate against measurement, compound 4: 3.6-fold (0.56 log units) below, outside the stated range (above it).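

In this assay, the same swap of phenyl for methyl on the core of compound 3 gives a 1.2-fold lower number from compound 3 to compound 4 (0.10 log units; within the scatter), so compound 3 and compound 4 cannot be told apart on this read-out. The gain seen on the first core therefore did not carry over in size to the second: the same change on two cores in this assay, a 5.7-fold lower number (0.76 log units; beyond the scatter) from compound 1 to compound 2 and a 1.2-fold lower number (0.10 log units; within the scatter) from compound 3 to compound 4, 4.6-fold (0.66 log units) apart, beyond the scatter of two such steps. This shows that a step measured on one core of this series cannot simply be transferred to another, but with a single pair on each core it does not show why the two steps differ, or whether either step would hold for other pairs on the same core.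

The compounds shown carry only phenyl or methyl at this place, so it remains open how a different group there, such as an amine, a carboxylic acid or a longer chain, would behave on either core. The difference between the two cores is also not broken down by any pair shown, which leaves open which part of it goes with the difference between the two steps.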